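From 4-hydroxyphenyl to 2-hydroxyphenyl: a small expected step

A few compounds are considered here, and "the series" means these few. Any claim that something is new, unique, unknown or untested is made for them only; others in the source may bear on it.

- compound 1 `CC1(C)[C@H]2CC[C@]1(C)N(Cc1cn(-c3cccc(Cl)c3)nn1)C(=O)C2`: 60 nM
- compound 2 `CC1(C)[C@H]2CC[C@]1(C)N(Cc1cn(-c3ccc(O)cc3)nn1)C(=O)C2`: 80 nM

Both values come from a functional assay on HepG2 cells (Homo sapiens) for inhibition, read by MTT assay, with a stated time of 24 h; on this read-out lower numbers stand for stronger inhibition and higher numbers for weaker inhibition. Among the compounds with values here, compound 2 stands within the usual scatter of compound 1, the only other measured compound, so the two cannot be ranked. The next compound, compound 3 `CC1(C)[C@H]2CC[C@]1(C)N(Cc1cn(-c3ccccc3O)nn1)C(=O)C2`, keeps the shared core and differs in one group, with 2-hydroxyphenyl in place of 4-hydroxyphenyl on an aromatic nitrogen. Within the data shown here, only one measured step bears on this change, and it involves the same aromatic nitrogen: a 1.3-fold higher number from compound 1 to compound 2 (0.12 log units; within the scatter). Among the measured compounds shown here, no measured compound carries the 2-hydroxyphenyl group, so this is weak, indirect guidance. No step beyond the scatter is therefore expected in this assay, and neither direction is favoured. The estimated step is a 1.3-fold higher number from compound 2 to compound 3 (0.10 log units; within the scatter). The estimate for compound 3 is 100 nM, with an expected range of 30 nM to 330 nM.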

Compound 3, half-maximal inhibitory concentration: 120 nM
Compound 3: the middle estimate sits 1.2-fold (0.08 log units) below what was measured, within the range that was stated.
By their numbers in this assay, from the lowest: compounds 1, 2 and 3 (each within the scatter of the next).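

In this assay, the step from 4-hydroxyphenyl to 2-hydroxyphenyl on the aromatic nitrogen is a 1.5-fold higher number from compound 2 to compound 3 (0.18 log units; within the scatter) and so cannot be ranked, even though the two compounds have the same atoms joined differently. The comparison with the chlorinated compound gives the same reading, with a 2.0-fold higher number from compound 1 to compound 3 (0.30 log units; within the scatter) and again no ranking. So far, these three groups on this nitrogen cannot be told apart on this read-out, and no measurement offered here explains that likeness.

All three groups shown are phenyl rings bearing a chlorine or a hydroxyl, so it remains open whether an amine or a carboxylic acid on that ring would give a clearly different number. From the compounds shown here alone, it also remains open what a longer alkyl chain in place of the ring would do.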